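The source may hold more compounds than are shown below. What is called first, only, known or untested is meant among the compounds shown, and "the series" means these compounds.

Working notes on the series. Among the compounds with values here, in a functional assay on A549 cells (Homo sapiens) for inhibition, read by CCK-8 assay, with a stated time of 72 h, tested at 2 uM (a lower number here means less inhibition of growth, a higher number more inhibition of growth at the concentration tested), compound 1 (`Nc1ccccc1NC(=O)c1ccc(CSc2cccc(F)c2)cc1`) gives 46.9% and sits within the scatter of the only other measured compound. Compound 2 (`Nc1ccccc1NC(=O)/C=C/c1ccc(CSCCc2ccccc2)cc1`) gives 45.7% in the same read-out, so the two stand level. Next is compound 3 (`Nc1ccccc1NC(=O)c1ccc(CSc2ccc(Cl)cc2)cc1`), which keeps the core of compound 1 and carries 4-chlorophenyl in place of 3-fluorophenyl on a sulfur, with 4-chlorophenyl in place of 3-fluorophenyl on a sulfur as the counted difference. Within the data shown here, no measured pair shows a change at this place, so the data give no direct guide to size or direction. The expected step of a number 0.9 percentage points lower from compound 1 to compound 3 (within the scatter) is therefore none beyond the scatter, and this remains a weakly founded expectation. For compound 3 the estimated value is 46% with 31% to 61% as the expected range in this assay before measurement.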

Compound 3, percent growth inhibition at one concentration: 47.3%
Beside the measured number, compound 3's estimate is 1.3 percentage points below it, and the stated range covers the measured number.
By their numbers in this assay, from the lowest: compounds 2, 1 and 3 (each within the scatter of the next).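

In this assay, within the data shown here, the first measured step at this place, 4-chlorophenyl in place of 3-fluorophenyl on a sulfur, reads as a number 0.4 percentage points higher from compound 1 to compound 3 (within the scatter). The sulfur and the shared core stay the same, so this exchange of one halogen-bearing phenyl group for another leaves the growth inhibition level at the concentration tested. No separate measurement bears on this result.

The step changes the halogen and its ring position together, so it cannot assign any share of the outcome to either one, and the compounds shown do not separate them. Also open, going by these compounds, is how the read-out responds to a group of a different kind on the sulfur, such as a phenyl ring carrying an amine or a carboxylic acid, or a longer chain in place of the ring.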